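Aryl amine in place of cyclohexyl on a shared core

The compounds below may be only part of what the source reports. "The series", "measured", "known", "first", "only" and "open" are said of these compounds alone.

Compound 1 `O=C1C(Nc2ccccc2F)=CC(=O)c2c1nc1n2[C@H]2OC[C@@H](O)[C@H]2OC1` and compound 2 `Cc1ccc(NC2=CC(=O)c3c(nc4n3[C@H]3OC[C@@H](O)[C@H]3OC4)C2=O)cc1` carry an aryl group on the amine nitrogen of a shared core; in a functional assay on MGC-803 cells (Homo sapiens) for inhibition, read by sulforhodamine B assay (on this read-out higher numbers stand for weaker inhibition and lower numbers for stronger inhibition), compound 1 gives 2000 nM and compound 2 gives 1550 nM, and the step of a 1.3-fold lower number from compound 1 to compound 2 (0.11 log units; within the scatter) stays within the scatter. Compound 3 `O=C1C=C(NC2CCCCC2)C(=O)c2c1nc1n2[C@H]2OC[C@@H](O)[C@H]2OC1` bears cyclohexyl there instead, and in this assay compound 3 reaches only a limit, > 8000 nM, so it sits at the limit of > 8000 nM in this assay, at which 1 of the 3 values shown sits, rather than at a number. Compound 4 `CCOc1ccccc1NC1=CC(=O)c2nc3n(c2C1=O)[C@H]1OC[C@@H](O)[C@H]1OC3` differs from compound 3 by 2-ethoxyphenyl in place of cyclohexyl on an amine nitrogen. Among the compounds with values here, no measured step joins a cyclohexyl to an aryl amine; the one measured step shows only that two aryl groups give close numbers, both of them measured values where compound 3 gives only a limit. The step expected in this assay is therefore downward, an at least 3.2-fold lower number from compound 3 to compound 4 (0.50 log units; beyond the scatter). Compound 4 is estimated at 2500 nM in this assay, between 900 nM and 7000 nM.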

Compound 4, half-maximal inhibitory concentration: 2450 nM
For compound 4 the middle estimate is 1.0-fold (0.01 log units) above the measured one; the range from low to high includes it.
By their numbers in this assay, from the lowest: compounds 2, 1 and 4 (each within the scatter of the next). At a limit, above all of these: compound 3.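

In this assay, the change to 2-ethoxyphenyl on an amine nitrogen gives the only step shown that joins a cyclohexyl to an aryl amine, and it lies beyond the scatter: an at least 3.2-fold lower number from compound 3 to compound 4 (0.51 log units; beyond the scatter). Compound 4 falls in with the other aryl amines, compounds 2, 1 and 4 each lying within the scatter of the next. The size of the step stays bounded on one side, since compound 3 gives a limit and not a number: the limit of > 8000 nM in this assay, at which 1 of the 4 values shown sits.

Going by these compounds, what an unsubstituted phenyl or a straight butyl chain on this nitrogen would give remains open. So does whether the aromatic ring alone carries the step.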